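Fluoro to Nitro on the Shared Core: Expecting Compound 4

The source may report more compounds than this note shows. Statements on the series, on what has been measured and on what is new or still open speak of the compounds shown alone.

Measured compounds:
compound 1 `O=C(Cc1cccnc1)c1cc2ccccc2[nH]1`: 13%
compound 2 `COc1ccc2[nH]c(C(=O)Cc3cccnc3)cc2c1`: "not determined" (no result reported)
compound 3 `O=C(Cc1cccnc1)c1cc2cc(F)ccc2[nH]1`: 24%

In an in vitro assay on P815B cells for inhibition of Indoleamine 2,3-dioxygenase 1 (Mus musculus), tested at 20 uM (a lower number here means less inhibition, a higher number more inhibition at the concentration tested (going by the name of the read-out)), compound 3 gives 24%, the higher of the two numbers available, with compound 1 giving 13%, a difference beyond the scatter; for compound 2 the result is "not determined" (no result reported). Compound 4 `O=C(Cc1cccnc1)c1cc2cc([N+](=O)[O-])ccc2[nH]1` differs from compound 3 in one place: nitro in place of fluoro on an aromatic carbon. Going by the values given here, the only measured step, a number 11 percentage points higher from compound 1 to compound 3 (beyond the scatter), is the sole guide; it and the present change both sit on an aromatic carbon of the shared core, but no measured pair follows the nitro group itself. A modest shift upward is therefore expected, of roughly the size seen before. Compound 4 is estimated at 32% (from 12% to 52%), an expected step of a number 8 percentage points higher from compound 3 to compound 4 (within the scatter).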

Compound 4, a percentage reported as inhibition, at one concentration (the size of the read-out at that concentration, not a potency): "not active" (no number reported)
Compound 4: no number reported, so the estimate cannot be set against anything.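

Going by these compounds alone, compound 4 is reported as not active, without a number, so no step from compound 3 to compound 4 can be read. The compounds shown leave open how nitro compares numerically with fluoro on the shared core. Nothing available bears on this result.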